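A few compounds are considered here, and "the series" means these few. Any claim that something is new, unique, unknown or untested is made for them only; others in the source may bear on it.

In a functional assay on NCI-H522 cells (Homo sapiens) for cytotoxicity, with a stated time of 3 days (on this read-out lower numbers stand for stronger inhibition and higher numbers for weaker inhibition), the measured compounds read:
- Compound 1 `CC#Cc1nc2ccccc2s1`: > 40000 nM, a limit
- Compound 2 `C#CCNC(=O)c1csc(C#Cc2ccccc2)n1`: > 40000 nM, a limit
- Compound 3 `C#CCNC(=O)c1csc(C#C)n1`: 2100 nM

Compound 2 stands at the limit of > 40000 nM in this assay, at which 2 of the 3 values shown sit, so it has a limit and no exact number. Any comparison that starts from compound 2 therefore has an open end.

Going by the values given here, the only measured step is an at least 19-fold lower number from compound 2 to compound 3 (1.27 log units; beyond the scatter), and it places hydrogen in place of phenyl on a triple-bonded carbon. Compound 4 `CCOC(=O)c1csc(C#Cc2ccccc2)n1` differs from compound 2 elsewhere: ethoxy in place of propargylamino on a carbonyl carbon. Among the compounds with values here, no measured step covers a change at that place, so the evidence is indirect. Within the data shown here, compound 4 keeps the phenyl that was lost in an at least 19-fold lower number from compound 2 to compound 3 (1.27 log units; beyond the scatter), and that step is the only one that took a compound off the limit.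

In this assay, then, no shift beyond the scatter is expected, and the data fix no direction for one. The expected step is a number no higher from compound 2 to compound 4 (the limit leaves the size open). A reading at the limit again is quite possible for this compound. The estimate for compound 4 is 40000 nM, with an expected range from 12000 nM to 80000 nM.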

Compound 4, half-maximal inhibitory concentration: > 40000 nM
Compound 4 was reported as a limit; the forecaster's own chance of this, stated with the estimate: 65%; the middle value sits exactly at the limit.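

In this assay, going by these compounds alone, compound 2 and compound 4 both read as a limit, so the change from propargylamino to ethoxy on the carbonyl carbon gives no step that can be read: the limit of > 40000 nM in this assay, at which 3 of the 4 values shown sit. On these data alone, what stays open is whether that change moves the number at all, as neither compound has an exact value here.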